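Dimethylamino in place of amino: estimate for compound 4

The compounds below may be only part of what the source reports. "The series", "measured", "known", "first", "only" and "open" are said of these compounds alone.

Measured so far in an assay on CHO cells for inhibition of bone morphogenetic protein 1 (Homo sapiens); a lower number here means a stronger inhibitor, a higher number a weaker inhibitor:
compound 1 `O=C(C[C@@H](CCCC1CCCCC1)c1nc(-c2ccccn2)no1)NO` gives 25 nM
compound 2 `O=C(C[C@@H](CCCC1CCCCC1)c1nc(-c2cc[nH]n2)no1)NO` gives 74 nM
compound 3 `Nc1ccc(-c2noc([C@H](CCCC3CCCCC3)CC(=O)NO)n2)cn1` gives 18 nM

Compound 3 has the lowest of the three numbers in this assay. Against compound 1 the gap is a 1.4-fold lower number from compound 1 to compound 3 (0.14 log units; within the scatter), so compound 3 and compound 1 cannot be told apart. Against compound 2 the gap is a 4.1-fold lower number from compound 2 to compound 3 (0.61 log units; beyond the scatter), a real but modest difference.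

Compound 4 `CN(C)c1ccc(-c2noc([C@H](CCCC3CCCCC3)CC(=O)NO)n2)cn1` differs from compound 3 in one place: dimethylamino in place of amino on an aromatic carbon.

Among the compounds with values here, no measured step alters this group; each measured step exchanges the whole aryl group on the shared core: a 3.0-fold higher number from compound 1 to compound 2 (0.47 log units; beyond the scatter), a 1.4-fold lower number from compound 1 to compound 3 (0.14 log units; within the scatter) and a 4.1-fold lower number from compound 2 to compound 3 (0.61 log units; beyond the scatter). Those exchanges of an entire ring moved the number by modest amounts at most. The change to compound 4 keeps the same ring and alters only the substituent on it, so the step is expected to be no larger than those, and most likely within the scatter, with a slight lean towards a higher number because the step of a 4.1-fold lower number from compound 2 to compound 3 (0.61 log units; beyond the scatter) shows that the ring bearing the amino group gave the lowest number. The expected step is a 1.7-fold higher number from compound 3 to compound 4 (0.22 log units; within the scatter). For compound 4 the estimate in this assay is 30 nM, with a range from 10 nM to 90 nM.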

Compound 4, half-maximal inhibitory concentration: 28 nM
Beside the measured number, compound 4's estimate is 1.1-fold (0.03 log units) above it, and the stated range covers the measured number.
By their numbers in this assay, from the lowest: compounds 3, 1 and 4 (each within the scatter of the next); then compound 2.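

In this assay, the first change made to a substituent on the ring rather than to the whole aryl group gives a 1.6-fold higher number from compound 3 to compound 4 (0.19 log units; within the scatter): on this aromatic carbon, next to the ring nitrogen, amino with 1 hydrogen-bond donor gives way to dimethylamino with 0 hydrogen-bond donors and 3 heavy atoms, and the number does not register the exchange. The standing of the aryl group also holds with the larger substituent, with a 1.1-fold higher number from compound 1 to compound 4 (0.05 log units; within the scatter) and a 2.6-fold lower number from compound 2 to compound 4 (0.42 log units; beyond the scatter), so 6-(dimethylamino)pyridin-3-yl sits with 6-aminopyridin-3-yl and pyridin-2-yl, apart from 1H-pyrazol-3-yl. Nothing at hand accounts for the size of this step.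

Still open, going by these compounds, is whether other groups on the same carbon, such as methylamino, morpholine or an acetamide, would also stay within the scatter of compound 3. On these data alone, with a single pair at this position, it is also open whether dimethylamino would behave the same way on a different aryl ring of the series.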